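Two Cores, One Swap: Chloro to Methoxy on NUGC Cells

The compounds below may be only part of what the source reports. "The series", "measured", "known", "first", "only" and "open" are said of these compounds alone.

Of the compounds shown here, three have been measured in a functional assay on NUGC cells (Homo sapiens) for cytotoxicity, read by sulforhodamine B assay, with a stated time of 24 h; a lower number here means a stronger inhibitor, a higher number a weaker inhibitor. Compound 1 `S=C(Nc1ccc(Cl)cc1)Nn1c(S)nnc1-c1ccncc1` gives 2120 nM in this assay. Compound 2 `COc1ccc(NC(=S)Nn2c(S)nnc2-c2ccncc2)cc1` gives 1820 nM in this assay. Compound 3 `Clc1ccc(Nc2nn3c(-c4ccncc4)nnc3s2)cc1`, which carries a different core, gives 1290 nM in this assay. The three values sit close together, and no one of them stands apart from the others.

Compounds 1 and 2 differ in one place only: methoxy in place of chloro on an aromatic carbon. This change gave a 1.2-fold lower number from compound 1 to compound 2 (0.07 log units; within the scatter), so the two compounds are indistinguishable within the usual variation of the measurement.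

Compound 4 `COc1ccc(Nc2nn3c(-c4ccncc4)nnc3s2)cc1` is not yet measured. It is related to compound 3 by the same change: methoxy in place of chloro on an aromatic carbon. The group that leaves, the group that enters and the place on the ring are the same as in the pair of compound 1 and compound 2. The difference between the core of compound 3 and the core of compound 1 is not broken down here.

Within the data shown here, the expectation for compound 4 rests on the one earlier instance of this change: a step of about a 1.2-fold lower number from compound 3 to compound 4 (0.07 log units; within the scatter) is expected, because the same change gave a 1.2-fold lower number from compound 1 to compound 2 (0.07 log units; within the scatter). For compound 4 the estimated value in this assay is 1100 nM, with a plausible range from 600 nM to 2000 nM. A single earlier step on a different core is a thin basis, so the range is kept wide.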

Compound 4, half-maximal inhibitory concentration: 56 nM
Estimate against measurement, compound 4: 20-fold (1.29 log units) above; measured number below the stated range.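

In this assay, putting methoxy in place of chloro on the core of compound 3 gave a 23-fold lower number from compound 3 to compound 4 (1.36 log units; beyond the scatter), a large gain in potency from a single small change. Among these compounds, the swap therefore did not carry over from one core to the other with the same size, so the result on the core of compound 1 was a poor guide to the result on the core of compound 3: the same change on two cores in this assay, a 1.2-fold lower number (0.07 log units; within the scatter) from compound 1 to compound 2 and a 23-fold lower number (1.36 log units; beyond the scatter) from compound 3 to compound 4, 20-fold (1.30 log units) apart, beyond the scatter of two such steps This shows that, in this series, the effect of the swap depends on the core it is made on, but it does not show which feature of the core matters or why, and with only one pair on each core it gives no general rule for other cores.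

The compounds shown leave open whether the large step is special to methoxy, or whether another group at the same place on the core of compound 3, such as ethoxy, hydroxyl or an amine, would also give a number far lower than that of compound 3. They also leave open how a longer chain such as butoxy would behave at that place on each of the two cores.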